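The compounds below may be only part of what the source reports. "The series", "measured", "known", "first", "only" and "open" are said of these compounds alone.

In an assay for inhibition of prostacyclin synthase (Homo sapiens), using microsomes (a lower number here means a stronger inhibitor, a higher number a weaker inhibitor), compound 2 `COc1ccccc1OC(C)(C)C1OCC(C/C=C\CCC(=O)O)C(c2cccnc2)O1` gives 51000 nM, the highest of the two numbers measured here. Compound 1 `O=C(O)CC/C=C\CC1COC(c2ccc(Cl)cc2Cl)OC1c1cccnc1` gives 2500 nM in this assay; the two structures differ in more than one place, so their gap cannot be tied to any single change. Compound 3 `CC(C)(Cc1ccc(F)cc1C#N)C1OCC(C/C=C\CCC(=O)O)C(c2cccnc2)O1` differs from compound 2 in one place: a group of 10 heavy atoms (8 carbon, 1 nitrogen, 1 fluorine; one six-membered aromatic ring of carbon only) in place of a group of 9 heavy atoms (7 carbon, 2 oxygen; one six-membered aromatic ring of carbon only), on a saturated chain carbon bound to two saturated chain carbons and a saturated ring carbon. Going by the values given here, no measured pair shows what such a swap does, so only a small step is expected, a 1.7-fold lower number from compound 2 to compound 3 (0.23 log units; within the scatter), in no sure direction. Compound 3 is expected to give 30000 nM in this assay, somewhere from 8000 nM to 120000 nM.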

Compound 3, half-maximal inhibitory concentration: 7000 nM
For compound 3 the middle estimate is 4.3-fold (0.63 log units) above the measured one; measured number outside the range, below it.
By their numbers in this assay, from the lowest: compound 1; then compound 3; then compound 2.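

At the saturated chain carbon bound to two saturated chain carbons and a saturated ring carbon, the group carried clearly matters in this assay: replacing 2-methoxyphenoxy with the group bearing a nitrile and a fluorine gives a 7.3-fold lower number from compound 2 to compound 3 (0.86 log units; beyond the scatter). Nothing measured here offers a reason for this step. The compounds shown leave open whether the nitrile, the fluorine or the link between aromatic ring and chain accounts for the step, and what an amine or a carboxylic acid would give at this position.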